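Open-chain pentenyl in place of the methylcyclohexenyl group

The source may hold more compounds than are shown below. What is called first, only, known or untested is meant among the compounds shown, and "the series" means these compounds.

Three measured analogues share one core and differ only in the group on an aromatic carbon of a six-membered aromatic ring with 1 nitrogen, next to the ring nitrogen. Compound 1 `CC(C(=O)NCc1ccc(C(F)(F)F)nc1Cl)c1ccc(NS(C)(=O)=O)c(F)c1` carries chloro there, and in an assay on CHO cells for antagonist activity at transient receptor potential cation channel subfamily V member 1 (Homo sapiens), read by FLIPR and calcium flux (a higher number here means a weaker inhibitor, a lower number a stronger inhibitor), compound 1 gives 0.2 nM. Compound 2 `Cc1nc(C(F)(F)F)ccc1CNC(=O)C(C)c1ccc(NS(C)(=O)=O)c(F)c1` carries methyl, and in this assay compound 2 gives 387 nM, so that a 1900-fold higher number from compound 1 to compound 2 (3.29 log units; beyond the scatter). Compound 3 `CC1C=C(c2nc(C(F)(F)F)ccc2CNC(=O)C(C)c2ccc(NS(C)(=O)=O)c(F)c2)CCC1` carries 3-methylcyclohex-1-en-1-yl; in this assay compound 3 gives 0.2 nM, level with compound 1 and together with it the lowest of the three numbers, since no change at the digits printed from compound 1 to compound 3 (within the scatter) while a 1900-fold lower number from compound 2 to compound 3 (3.29 log units; beyond the scatter).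

Compound 4 `CCC/C=C/c1nc(C(F)(F)F)ccc1CNC(=O)C(C)c1ccc(NS(C)(=O)=O)c(F)c1` makes the change (pent-1-en-1-yl in place of 3-methylcyclohex-1-en-1-yl on an aromatic carbon). Within the data shown here, the steps that bear on it are a 1900-fold lower number from compound 2 to compound 3 (3.29 log units; beyond the scatter), which was large, and no change at the digits printed from compound 1 to compound 3 (within the scatter), which was not. The entering pent-1-en-1-yl keeps a double bond outside aromatic rings but has no ring and is smaller than what leaves, yet larger than the methyl of compound 2. Compound 4 is therefore expected to stay close to compound 3, with at most a modest rise, a 3.0-fold higher number from compound 3 to compound 4 (0.48 log units; beyond the scatter). The estimate for compound 4 is 0.6 nM, in a range of 0.1 nM to 5 nM.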

Compound 4, inhibition constant: 0.9 nM
Estimate against measurement, compound 4: 1.5-fold (0.18 log units) below; measured number inside the range.
By their numbers in this assay, from the lowest: compounds 1 and 3 (each within the scatter of the next); then compound 4; then compound 2.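

At this position a ring is not needed for most of the drop from the methyl compound in this assay: the open-chain pent-1-en-1-yl group gives a 430-fold lower number from compound 2 to compound 4 (2.63 log units; beyond the scatter), so the large gain seen earlier with 3-methylcyclohex-1-en-1-yl is not confined to that cyclic group. Opening the ring and shortening the group to pent-1-en-1-yl still has a modest cost, a 4.5-fold higher number from compound 3 to compound 4 (0.65 log units; beyond the scatter), and the same modest gap separates the chain from chloro, a 4.5-fold higher number from compound 1 to compound 4 (0.65 log units; beyond the scatter). The compounds shown cannot separate the loss of the ring from the smaller count of heavy atoms, and they leave open whether a saturated pentyl chain, a phenyl ring or an amine at this position would stay as low as compound 4. No measurement here accounts for any of these steps.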